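A few compounds are considered here, and "the series" means these few. Any claim that something is new, unique, unknown or untested is made for them only; others in the source may bear on it.

Compound 1 `CC1(C)CC(NC(=O)Nc2cccc(Cl)c2)c2cc(Br)ccc2O1`: 69000 nM
Compound 2 `CC1(C)CC(NC(=O)Nc2ccc(Cl)cc2)c2cc(Cl)ccc2O1`: 19000 nM
Compound 3 `CC1(C)CC(NC(=O)Nc2ccc(Cl)cc2)c2cc(Br)ccc2O1`: 25000 nM

All three were tested in a functional assay on U-373MG ATCC cells (Homo sapiens) for inhibition, read by MTT assay, with a stated time of 72 h; a higher number here means a weaker inhibitor, a lower number a stronger inhibitor. Compound 2 and compound 3 carry the same urea part and differ only in their cores: chloro in place of bromo on an aromatic carbon. That change leaves the result essentially where it was, since the step of a 1.3-fold higher number from compound 2 to compound 3 (0.12 log units; within the scatter). In this assay compound 2 gives 19000 nM and compound 3 gives 25000 nM, two numbers that cannot be told apart.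

The second change sits on the other side of the urea. Compound 3 and compound 1 share the same core, but (3-chlorophenyl in place of 4-chlorophenyl on an amide-type nitrogen). Here the result does move: the step of a 2.8-fold higher number from compound 3 to compound 1 (0.44 log units; beyond the scatter), and compound 1 gives 69000 nM.

Compound 4 `CC1(C)CC(NC(=O)Nc2cccc(Cl)c2)c2cc(Cl)ccc2O1` has not yet been measured. It relates to compound 2 exactly as compound 1 relates to compound 3: 3-chlorophenyl in place of 4-chlorophenyl on an amide-type nitrogen. The place of the change is described in the same words in both pairs, so it is the same change, now carried on the core of compound 2 rather than that of compound 3. Because the step of a 1.3-fold higher number from compound 2 to compound 3 (0.12 log units; within the scatter) shows that the core swap itself hardly matters, the expected effect on compound 4 is that the step of a 2.8-fold higher number from compound 2 to compound 4 (0.45 log units; beyond the scatter) should be of the same size as the earlier one. On that basis compound 4 is estimated at 53000 nM, with a likely range from 25000 nM to 110000 nM.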

Compound 4, half-maximal inhibitory concentration: 21000 nM
Compound 4: middle estimate off by 2.5-fold (0.40 log units), on the high side; the whole stated range lies above it.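

In this assay, putting 3-chlorophenyl in place of 4-chlorophenyl on the core of compound 2 gives a 1.1-fold higher number from compound 2 to compound 4 (0.04 log units; within the scatter), so these two compounds cannot be told apart, while chloro in place of bromo on an aromatic carbon, with the 3-chlorophenyl group kept, gives a 3.3-fold lower number from compound 1 to compound 4 (0.52 log units; beyond the scatter). The chlorophenyl change therefore reads as a real step on one core and as no clear step on the other, yet the gap between those two readings is no larger than repeated measurements could produce: the same change on two cores in this assay, a 2.8-fold higher number (0.44 log units; beyond the scatter) from compound 3 to compound 1 and a 1.1-fold higher number (0.04 log units; within the scatter) from compound 2 to compound 4, 2.5-fold (0.40 log units) apart, within the scatter of two such steps The halogen change on the core looks the same when its two steps are compared, so these compounds neither show that either change depends on the group elsewhere in the molecule nor prove that it carries over unchanged: the same change on two cores in this assay, a 1.3-fold higher number (0.12 log units; within the scatter) from compound 2 to compound 3 and a 3.3-fold higher number (0.52 log units; beyond the scatter) from compound 4 to compound 1, 2.5-fold (0.40 log units) apart, within the scatter of two such steps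

As far as these compounds go, it remains open whether a methoxy group or a carboxylic acid in place of the chlorine on the phenyl ring would move the number in this assay by more than these steps. Also open is whether fluoro in place of chloro or bromo on the aromatic carbon of the core would behave as the two halogens shown here do.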